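A methoxy added to compound 3 at the limit

The source may hold more compounds than are shown below. What is called first, only, known or untested is meant among the compounds shown, and "the series" means these compounds.

Compound 1 `CCOCn1cc(C#N)c2c(N)ncnc21`: > 100000 nM
Compound 2 `COCCOCn1cc(C#N)c2c(N)ncnc21`: > 100000 nM
Compound 3 `CCOCn1cc(C(N)=O)c2c(N)ncnc21`: > 100000 nM

All three entries come from a functional assay on KB cells (Homo sapiens) for cytotoxicity (on this read-out higher numbers stand for weaker inhibition and lower numbers for stronger inhibition), and each is a limit rather than a number. Compound 3 stands at > 100000 nM, which is a limit. It shares this position with the other two compounds: the limit of > 100000 nM in this assay, at which 3 of the 3 values shown sit.

Compound 4 `COCCOCn1cc(C(N)=O)c2c(N)ncnc21` differs from compound 3 by one change: methoxy in place of hydrogen on a saturated chain carbon, two bonds along the chain from an oxygen on a saturated carbon. Methoxy takes the place of hydrogen on a saturated chain carbon, two bonds along the chain from an oxygen on a saturated carbon. The same difference, cut one bond further out, reads ethyl to 2-methoxyethyl.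

The same change was measured once on the nitrile compound, as a step that the two limits leave unreadable from compound 1 to compound 2. The other measured step, with carbamoyl in place of cyano, is a step that the two limits leave unreadable from compound 1 to compound 3. Neither has a readable size, so neither gives a direction. Compound 2 carries the methoxy and still gives > 100000 nM, a limit. No step beyond the scatter is therefore expected in either direction, and another limit is the likeliest report. The expected result is a step that the limit leaves unreadable from compound 3 to compound 4. For compound 4 the estimate is 130000 nM, with an expected range from 50000 nM to 300000 nM.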

Compound 4, half-maximal inhibitory concentration: > 100000 nM
Compound 4: a limit, no number; the forecaster's own chance of this, stated with the estimate: 90%; the middle value is on the limit's open side.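

Compound 4 also stands at a limit, so neither its step from compound 3 nor its step from compound 2 can be read, and neither change gains a size: the limit of > 100000 nM in this assay, at which 4 of the 4 values shown sit. The compounds shown leave open how strongly any of the four acts in this assay, and whether the methoxy or the carbamoyl change shifts that at all.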